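A few compounds are considered here, and "the series" means these few. Any claim that something is new, unique, unknown or untested is made for them only; others in the source may bear on it.

Of the compounds shown here, three sharing one core have been measured in a functional assay on HL-60 cells (Homo sapiens) for antiproliferative activity, read by MTT assay, with a stated time of 72 h; a lower number here means a stronger inhibitor, a higher number a weaker inhibitor. Compound 1 `CCC(=O)N(C)c1ccc2[nH]c(-c3n[nH]c4ccccc34)cc2n1` gives 6130 nM. Compound 2 `CN(C(=O)C(C)(C)C)c1ccc2[nH]c(-c3n[nH]c4ccccc34)cc2n1` gives 4990 nM. Compound 3 `CN(C(=O)c1ccc(Br)cc1)c1ccc2[nH]c(-c3n[nH]c4ccccc34)cc2n1` gives 1080 nM. Compound 2 thus stands second highest of the three numbers, close to compound 1 and well apart from compound 3: the step of a 1.2-fold lower number from compound 1 to compound 2 (0.09 log units; within the scatter) lay within the scatter, whereas a 4.6-fold lower number from compound 2 to compound 3 (0.66 log units; beyond the scatter) and a 5.7-fold lower number from compound 1 to compound 3 (0.75 log units; beyond the scatter) lay beyond it.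

Compound 4 `CN(C(=O)c1ccc([N+](=O)[O-])cc1)c1ccc2[nH]c(-c3n[nH]c4ccccc34)cc2n1` has not been measured. It differs from compound 2 in one place: 4-nitrophenyl in place of tert-butyl on a carbonyl carbon. The measured step that bears on this is a 4.6-fold lower number from compound 2 to compound 3 (0.66 log units; beyond the scatter), in which a 4-bromophenyl group took the place of the same tert-butyl group on the carbonyl carbon, a modest but real change. Going by the values given here, no measured pair shows whether a 4-nitrophenyl group behaves like a 4-bromophenyl group, so the expectation is a step of similar size in the same direction, with a wide range around it. Compound 4 is therefore expected to give 1500 nM, with a range from 500 nM to 5000 nM, which amounts to an expected 3.3-fold lower number from compound 2 to compound 4 (0.52 log units; beyond the scatter).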

Compound 4, half-maximal inhibitory concentration: 6800 nM
The estimate for compound 4 lay 4.5-fold (0.66 log units) below the measured number; measured number outside the range, above it.
By their numbers in this assay, from the lowest: compound 3; then compounds 2, 1 and 4 (each within the scatter of the next).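

In this assay, putting an aromatic ring on the carbonyl carbon does not by itself go with a lower number: 4-nitrophenyl in place of tert-butyl gives only a small step (a 1.4-fold higher number from compound 2 to compound 4 (0.13 log units; within the scatter)), and 4-nitrophenyl in place of ethyl gives another (a 1.1-fold higher number from compound 1 to compound 4 (0.05 log units; within the scatter)), both within the scatter. Going by these compounds alone, the group carried on that ring turns out to matter, which the earlier compounds could not show, as nitro in place of bromo on an aromatic carbon gives a step beyond the scatter (a 6.3-fold higher number from compound 3 to compound 4 (0.80 log units; beyond the scatter)). Nothing available explains this difference between nitro and bromo.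

Still open, going by these compounds, is how a plain phenyl, or a ring carrying chloro, methoxy or an amine in the place of bromo, would compare with compound 3. A longer chain on the carbonyl carbon is also untested among the compounds shown here.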